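Thiophen-2-yl in place of pyridin-4-yl on the ketone

This account rests on a few compounds, and the source may have more. Where it says the series, first, only, none or still open, it means among the compounds named here.

In a functional assay on BXPC-3 cells (Homo sapiens) for antiproliferative activity, read by sulforhodamine B assay, with a stated time of 72 h (on this read-out higher numbers stand for weaker inhibition and lower numbers for stronger inhibition), compound 1 `CC(C)(C)c1[nH]cnc1/C=c1\[nH]c(=O)/c(=C/c2cccc(C(=O)c3ccccc3)c2)[nH]c1=O` gives 0.63 nM, and compound 3 `CC(C)(C)c1[nH]cnc1/C=c1\[nH]c(=O)/c(=C/c2cccc(C(=O)c3ccncc3)c2)[nH]c1=O` gives 23.8 nM. Compound 3 therefore holds the higher of the two true numbers, and compound 1 is its nearest neighbour. Compound 2 `CC(C)(C)c1[nH]cnc1/C=c1\[nH]c(=O)/c(=C/c2cccc(C(=O)N3CCC3)c2)[nH]c1=O` reads > 500 nM, which is a limit of this assay and not a number.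

The next step leads to compound 4 `CC(C)(C)c1[nH]cnc1/C=c1\[nH]c(=O)/c(=C/c2cccc(C(=O)c3cccs3)c2)[nH]c1=O`, which differs from compound 3 as follows: thiophen-2-yl in place of pyridin-4-yl on a carbonyl carbon. In words, thiophen-2-yl stands in place of pyridin-4-yl on a carbonyl carbon.

Three measured steps at this same carbonyl carbon bear on the change. Pyridin-4-yl in place of phenyl gave a 38-fold higher number from compound 1 to compound 3 (1.58 log units; beyond the scatter). Azetidin-1-yl in place of phenyl gave an at least 790-fold higher number from compound 1 to compound 2 (2.89 log units; beyond the scatter), and pyridin-4-yl in place of azetidin-1-yl gave an at least 21-fold lower number from compound 2 to compound 3 (1.32 log units; beyond the scatter). All three are large, and the two aromatic ketones with true numbers both lie on the low side of the azetidin-1-yl amide. Thiophen-2-yl carries no nitrogen, as phenyl carries none, so a move back towards compound 1 is expected, though no measured step tests a five-membered ring. For this reason only part of the gap is expected to close. The expected change is a 7.9-fold lower number from compound 3 to compound 4 (0.90 log units; beyond the scatter), a step to a lower number beyond the scatter. The estimate for compound 4 is 3 nM, with an expected range of 0.7 nM to 15 nM.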

Compound 4, half-maximal inhibitory concentration: 1.72 nM
Compound 4: the middle estimate sits 1.7-fold (0.24 log units) above what was measured; measured number inside the range.
By their numbers in this assay, from the lowest: compound 1; then compound 4; then compound 3. At a limit, above all of these: compound 2.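

In this assay, this carbonyl carbon accepts a five-membered aromatic ring: thiophen-2-yl recovers most of the ground lost with pyridin-4-yl, giving a 14-fold lower number from compound 3 to compound 4 (1.14 log units; beyond the scatter), while a 2.7-fold higher number from compound 1 to compound 4 (0.44 log units; beyond the scatter) leaves a modest gap that still lies beyond the scatter. Ring size alone therefore does not set the order among the aromatic ketones, as the five-membered ring of compound 4 reads closer to compound 1 than to the six-membered ring of compound 3. Against the azetidin-1-yl amide the change gives an at least 290-fold lower number from compound 2 to compound 4 (2.46 log units; beyond the scatter), a step that rests on a limit and not a number: the limit of > 500 nM in this assay, at which 1 of the 4 values shown sits.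

On these data alone, whether the low numbers extend to furan-2-yl or pyridin-3-yl on the same carbonyl carbon remains open, and the single nitrogen-bearing ring here cannot show whether the ring nitrogen itself or its placement accounts for the rise at compound 3. Equally open, as far as these compounds go, is whether an aminomethyl group or a carboxylic acid on the thiophen-2-yl ring would keep a compound near compound 4.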